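The source may report more compounds than this note shows. Statements on the series, on what has been measured and on what is new or still open speak of the compounds shown alone.

In a functional assay on the whole organism (Tail, strain ICR) with Mus musculus as the target, in the tail flick test, with a stated time of 90 min, at a dose of 25 umol/kg by the oral route (on this read-out higher numbers stand for a stronger effect at the one dose given and lower numbers for a weaker effect), three compounds have been measured:

compound 1 `C[C@H](NC(=O)CN(c1nc(Cl)nc2[nH]cnc12)C1CC1)C(=O)OCc1ccccc1`: 44.2%
compound 2 `CC(C)[C@H](NC(=O)CN(c1nc(Cl)nc2[nH]cnc12)C1CC1)C(=O)OCc1ccccc1`: 51.3%
compound 3 `O=C(CN(c1nc(Cl)nc2[nH]cnc12)C1CC1)N[C@@H](CCC(=O)OCc1ccccc1)C(=O)OCc1ccccc1`: 50%

Compound 3 gives the second highest of these three numbers; the difference a number 1.3 percentage points lower from compound 2 to compound 3 (within the scatter) and the difference a number 5.8 percentage points higher from compound 1 to compound 3 (within the scatter) both lie within the usual scatter, so the three compounds are not separated by these results. Compound 4 `CC(C)C[C@H](NC(=O)CN(c1nc(Cl)nc2[nH]cnc12)C1CC1)C(=O)OCc1ccccc1` differs from compound 3 by isopropyl in place of (benzyloxycarbonyl)methyl on a saturated chain carbon, two bonds along the chain from an amide-type nitrogen and a carbonyl carbon. Among the measured compounds shown here, two measured steps bear on this change in side chain: a number 7.1 percentage points higher from compound 1 to compound 2 (within the scatter) and a number 1.3 percentage points lower from compound 2 to compound 3 (within the scatter), each within the scatter. For the measured compounds named here, no step between the measured compounds has gone beyond the scatter, so for compound 4 no change beyond the scatter is expected in this assay, with an estimated step of no change at the digits printed from compound 3 to compound 4 (within the scatter). Compound 4 is therefore estimated at 50%, expected between 38% and 62%.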

Compound 4, a percentage reported as activity, at one dose (the size of the read-out at that dose, not a potency): 15.2%
Beside the measured number, compound 4's estimate is 34.8 percentage points above it; the measured number lies below the stated range.
By their numbers in this assay, from the lowest: compound 4; then compounds 1, 3 and 2 (each within the scatter of the next).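

In this assay, among the compounds shown here, the side chain at this carbon proves able to change the result: isobutyl gives a number 34.8 percentage points lower from compound 3 to compound 4 (beyond the scatter) and a number 36.1 percentage points lower from compound 2 to compound 4 (beyond the scatter) and also a number 29 percentage points lower from compound 1 to compound 4 (beyond the scatter) as the first steps here that lie beyond the scatter. Methyl, isopropyl and 2-(benzyloxycarbonyl)ethyl remain within the scatter of one another, so isobutyl alone stands apart among these four side chains. No available evidence explains why isobutyl differs from the other three. Going by these compounds, whether a straight butyl chain, a terminal amine or a free carboxylic acid would stand with isobutyl or with the other three remains open.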